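Notes on the amide change from compound 3 to compound 4

This account rests on a few compounds, and the source may have more. Where it says the series, first, only, none or still open, it means among the compounds named here.

Values so far in an assay on HEK-293T cells for inhibition of phospholipase A and acyltransferase 2 (Homo sapiens), with stated times of 30 min and 20 min; a higher number here means a weaker inhibitor, a lower number a stronger inhibitor:
compound 1 `O=C(CCc1ccc(Cl)cc1)C(=O)NCCCCc1ccccc1`: 631 nM
compound 2 `O=C(CCc1ccccc1)[C@H](F)C(=O)NCc1ccccc1`: a limit only, > 10000 nM
compound 3 `CCNC(=O)C(=O)CCc1ccc(Cl)cc1`: 2510 nM

Compound 3 holds the highest of the two numbers given. Among the compounds with values here, the nearest numbered neighbour is compound 1, and the only step between two numbered values is a 4.0-fold higher number from compound 1 to compound 3 (0.60 log units; beyond the scatter), a modest change on the amide side of the shared core. Compound 2 sits at the limit of > 10000 nM in this assay, at which 1 of the 3 values shown sits, and contributes no number; it also differs from the others in more than one place, so nothing is drawn from it here.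

Compound 4 `O=C(CCc1ccc(Cl)cc1)C(=O)N1CCCCC1` carries piperidin-1-yl in place of ethylamino on a carbonyl carbon. Within the data shown here, no measured step touches this kind of change: the one step that alters the amide substituent, from compound 1 to compound 3, changes the chain length, not the hydrogen on the nitrogen, and was only modest. What the step from compound 3 to compound 4 does to the amide hydrogen is therefore unsupported by any measured pair, and the expected size is taken as small to modest, with the direction uncertain and a lean towards a weaker inhibitor.

Compound 4 is thus estimated at 4000 nM, within 1200 nM to 15000 nM, which is an expected step of a 1.6-fold higher number from compound 3 to compound 4 (0.20 log units; within the scatter).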

Compound 4, half-maximal inhibitory concentration: > 10000 nM
Compound 4 was reported as a limit; the forecaster's own chance of this, stated with the estimate: 25%; at least 2.5-fold (0.39 log units) between middle value and limit.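

In this assay, within the data shown here, piperidin-1-yl in place of ethylamino on a carbonyl carbon brings an at least 3.9-fold higher number from compound 3 to compound 4 (0.60 log units; beyond the scatter), the first measured change here that leaves the amide nitrogen without its hydrogen. The group that enters has no hydrogen-bond donor where ethylamino has one, whereas a 4.0-fold higher number from compound 1 to compound 3 (0.60 log units; beyond the scatter) is a step in which both compounds keep the amide hydrogen, and there the compound with the larger amide substituent gives the lower number, so more heavy atoms on the amide do not by themselves go with a weaker inhibitor in this pair. Compound 4 is reported only as a limit, not as a number, so the full size of its step remains unknown, and it joins compound 2 at that limit: the limit of > 10000 nM in this assay, at which 2 of the 4 values shown sit.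

The step from ethylamino to piperidin-1-yl changes the amide hydrogen and introduces a ring together, so it cannot say which of the two matters. A diethylamino amide, with no amide hydrogen and no ring, and a cyclohexylamino amide, with the hydrogen and a ring, would pull these two changes apart.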